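Chloro for Methyl on the Thiophene of Compound 2

The source may hold more compounds than are shown below. What is called first, only, known or untested is meant among the compounds shown, and "the series" means these compounds.

Two analogues sharing one core have been measured in a functional assay on Jurkat cells for inhibition of nuclear factor NF-kappa-B complex (Homo sapiens); on this read-out higher numbers stand for weaker inhibition and lower numbers for stronger inhibition. Compound 1 `CCOC(=O)c1cnc(-c2ccc(Cl)cc2)nc1NN1C(=O)C=C(C)C1=O` carries a 4-chlorophenyl group, and in this assay compound 1 gives 300 nM. Compound 2 `CCOC(=O)c1cnc(-c2ccc(C)s2)nc1NN1C(=O)C=C(C)C1=O` carries a 5-methylthiophen-2-yl group in its place, and in this assay compound 2 gives 200 nM. The step of a 1.5-fold lower number from compound 1 to compound 2 (0.18 log units; within the scatter) separates them, so compound 2 sits at one end of the pair of numbers without being set apart from compound 1 beyond the scatter.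

Compound 3 `CCOC(=O)c1cnc(-c2ccc(Cl)s2)nc1NN1C(=O)C=C(C)C1=O` differs from compound 2 by chloro in place of methyl on an aromatic carbon. Among the measured compounds shown here, no measured step swaps methyl for chloro on the same ring; the only step recorded, a 1.5-fold lower number from compound 1 to compound 2 (0.18 log units; within the scatter), exchanges whole aryl groups and is itself small. With nothing pointing to a sizeable move in either direction, a step within the scatter is expected for compound 3, a 1.3-fold higher number from compound 2 to compound 3 (0.10 log units; within the scatter). Compound 3 is therefore estimated at 250 nM in this assay, with a range from 100 nM to 600 nM.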

Compound 3, half-maximal inhibitory concentration: 300 nM
Estimate against measurement, compound 3: 1.2-fold (0.08 log units) below; the measured number falls inside the stated range.
By their numbers in this assay, from the lowest: compounds 2, 1 and 3 (each within the scatter of the next).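

In this assay, among the compounds shown here, the exchange of methyl for chloro on the aromatic carbon next to the ring sulfur, the first change confined to this position, amounts to a 1.5-fold higher number from compound 2 to compound 3 (0.18 log units; within the scatter), so the two groups cannot be told apart here. With a chloro group on both aryl groups, 5-chlorothiophen-2-yl in place of 4-chlorophenyl gives no change at the digits printed from compound 1 to compound 3 (within the scatter), which adds a comparison of the two aryl groups that differs from the earlier one, where the chloro group was exchanged along with the ring. No independent data bear on these results, so the steps can be reported but not explained.

Going by these compounds, since all three numbers lie within the scatter of one another, it remains open whether any group at this position, such as an amine, a carboxylic acid or a longer alkyl chain in place of methyl or chloro, would shift the number beyond the scatter. On these data alone, it also remains open whether these small steps would hold with the rest of the shared core changed, for example with a carboxylic acid in place of the ethyl ester.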